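Thiophen-3-yl in place of propyl on a thiophene ring

The compounds below may be only part of what the source reports. "The series", "measured", "known", "first", "only" and "open" are said of these compounds alone.

Of the compounds shown here, two from a shared core carrying a thienylmethylamine have been read in an ADME assay on MDCK cells (Canis lupus familiaris) for cytotoxicity, read by microscopy, with a stated time of 48 h; on this read-out lower numbers stand for higher toxicity in this test and higher numbers for lower toxicity in this test. Compound 1 `CCCc1ccsc1CN[C@@H]1C[C@H]2C[C@@H]([C@H]1C)C2(C)C` gives 50000 nM and stands as the higher of the two numbers. Compound 2 `CCc1csc(CN[C@@H]2C[C@H]3C[C@@H]([C@H]2C)C3(C)C)c1` gives 25000 nM in this assay, a number that lies within the scatter of that of compound 1, so the two are not distinguished here. Among the measured compounds shown here, no step between measured compounds is available, and the pair does not speak to the change now considered.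

Compound 3 `C[C@H]1[C@H](NCc2sccc2-c2ccsc2)C[C@H]2C[C@@H]1C2(C)C` carries thiophen-3-yl in place of propyl on an aromatic carbon; the group sits on an aromatic carbon of a five-membered aromatic ring with 1 sulfur, next to the ring atom that bears a large group, two ring bonds from the ring sulfur. With nothing measured on this change, the step of a 2.0-fold lower number from compound 1 to compound 3 (0.30 log units; within the scatter) is expected to be small, leaning toward a lower number but not clearly beyond the scatter. Compound 3 is therefore estimated at 25000 nM, with a range from 10000 nM to 100000 nM in this assay.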

Compound 3, minimum cytotoxic concentration: 12500 nM
Estimate against measurement, compound 3: 2.0-fold (0.30 log units) above; low and high end bracket the measured number.
By their numbers in this assay, from the lowest: compounds 3, 2 and 1 (each within the scatter of the next, the first and the last beyond it).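

In this assay, thiophen-3-yl in place of propyl on an aromatic carbon gives a 4.0-fold lower number from compound 1 to compound 3 (0.60 log units; beyond the scatter), so this position, next to the ring atom that bears a large group, can change the read-out beyond the scatter. Among the compounds shown here, the earlier compounds offered no step at all, and this single modest step is the first sign that the group at this place matters in this test. Nothing available gives a reason for the step.

The compounds shown leave open whether the change follows from the ring of thiophen-3-yl or from the larger group as such. Going by these compounds, a phenyl ring, a butyl chain or a primary amine at this place would help separate those readings, and the same change on another core remains untested here.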